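A few compounds are considered here, and "the series" means these few. Any claim that something is new, unique, unknown or untested is made for them only; others in the source may bear on it.

Measured compounds:
- compound 1, `CC1=CC[C@@H]([C@@](C)(O)CCCC(C)(C)NC=S)CC1`: 72000 nM
- compound 2, `CC1=CC[C@@H]([C@@](C)(O)CCCC(C)(C)NC(=S)N/N=C\c2ccc(C)cc2)CC1`: 45700 nM
- compound 3, `CC1=CC[C@@H]([C@@](C)(O)CCCC(C)(C)NC(=S)N/N=C\c2ccccc2[N+](=O)[O-])CC1`: > 100000 nM (a limit, not a number)

All three were tested in a functional assay on PCO3 cells (Homo sapiens) for cytotoxicity, read by sulforhodamine B assay; a higher number here means a weaker inhibitor of growth, a lower number a stronger inhibitor of growth. Compound 1 gives 72000 nM. Compound 2 gives 45700 nM. On these data alone, for compound 3 the assay reports only a limit, > 100000 nM, so its true value is unknown beyond that edge; it sits at the limit of > 100000 nM in this assay, at which 1 of the 3 values shown sits. For the measured compounds named here, the one measured step at this position is an at least 2.1-fold higher number from compound 2 to compound 3 (0.34 log units; beyond the scatter), a weakening when 2-nitrophenyl replaced 4-methylphenyl.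

Compound 4, `CC1=CC[C@@H]([C@@](C)(O)CCCC(C)(C)NC(=S)N/N=C\c2cccc(Cl)c2)CC1`, is not yet measured. It differs from compound 3 as follows: 3-chlorophenyl in place of 2-nitrophenyl on a carbon with a double bond to nitrogen. This removes the very group that accompanied the limit in compound 3, and the aromatic group in compound 4 carries no hydrogen-bond acceptor, as in compound 2. Going by the values given here, with only one step measured, the expectation is modest: compound 4 is estimated to come back toward the range of compound 2, a step of an at least 1.6-fold lower number from compound 3 to compound 4 (0.22 log units; that floor lies within the scatter) in this assay. The estimate for compound 4 is 60000 nM, within 25000 nM to 150000 nM, with a real chance that only a limit is reported again.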

Compound 4, concentration for total growth inhibition: 37800 nM
Compound 4: middle estimate off by 1.6-fold (0.20 log units), on the high side; measured number inside the range.
By their numbers in this assay, from the lowest: compounds 4, 2 and 1 (each within the scatter of the next). At a limit, above all of these: compound 3.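

In this assay, 3-chlorophenyl in place of 2-nitrophenyl gives an at least 2.6-fold lower number from compound 3 to compound 4 (0.42 log units; beyond the scatter), so the loss seen earlier at this position is not shared by every substituted phenyl group. The other comparison gives a 1.2-fold lower number from compound 2 to compound 4 (0.08 log units; within the scatter), so 3-chlorophenyl and 4-methylphenyl cannot be told apart here, even though the two groups differ in both substituent and printed ring number. Compound 3 is reported only as a limit, not as a number, so the full size of its step remains unknown: the limit of > 100000 nM in this assay, at which 1 of the 4 values shown sits.

These compounds cannot separate the nitro group itself from its place on the ring, since 2-nitrophenyl and 3-chlorophenyl differ in both. They also leave open how an aminophenyl or a carboxyphenyl group would read on this carbon in this assay.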